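Moving one chlorine: what compound 4 may show

The source may report more compounds than this note shows. Statements on the series, on what has been measured and on what is new or still open speak of the compounds shown alone.

In a functional assay on C8166 cells (Homo sapiens) for cytotoxicity, read by MTT assay (on this read-out higher numbers stand for lower toxicity in this test and lower numbers for higher toxicity in this test), the measured compounds give
compound 1 `Cc1ccc(C(=O)Nc2cc(Cl)ccc2OCC(=O)Nc2ccc(S(N)(=O)=O)cc2C)cc1`: 54200 nM
compound 2 `Cc1cc(S(N)(=O)=O)ccc1NC(=O)COc1ccc(Cl)cc1NC(=O)c1cccc(C(F)(F)F)c1`: 124000 nM
compound 3 `Cc1cc(S(N)(=O)=O)ccc1NC(=O)COc1ccc(Cl)cc1NC(=O)c1ccc(Cl)c(Cl)c1`: 158000 nM

Compound 3 sits at the high end of these numbers, level with compound 2 and clear of compound 1. Compound 4 `Cc1cc(S(N)(=O)=O)ccc1NC(=O)COc1ccc(Cl)cc1NC(=O)c1cc(Cl)cc(Cl)c1` carries 3,5-dichlorophenyl in place of 3,4-dichlorophenyl on a carbonyl carbon. All three measured steps changed the group at this same place. The two that replaced 4-methylphenyl were modest (a 2.3-fold higher number from compound 1 to compound 2 (0.36 log units; beyond the scatter)) (a 2.9-fold higher number from compound 1 to compound 3 (0.46 log units; beyond the scatter)). Going by the values given here, the one between the remaining groups stayed small (a 1.3-fold higher number from compound 2 to compound 3 (0.11 log units; within the scatter)). For this swap in this assay, no step beyond the scatter is therefore expected (a 1.2-fold lower number from compound 3 to compound 4 (0.07 log units; within the scatter)). Compound 4 is estimated at 135000 nM, with an expected range from 65000 nM to 260000 nM.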

Compound 4, half-maximal cytotoxic concentration: 72400 nM
For compound 4 the middle estimate is 1.9-fold (0.27 log units) above the measured one; the measured number falls inside the stated range.
By their numbers in this assay, from the lowest: compounds 1, 4, 2 and 3 (each within the scatter of the next, the first and the last beyond it).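

Moving one chlorine on the ring, with the atom counts unchanged, is enough to leave the scatter in this assay (a 2.2-fold lower number from compound 3 to compound 4 (0.34 log units; beyond the scatter)), so at this place the arrangement of the chlorines counts and not only their presence. Compound 4 nevertheless stays within the scatter of the other two groups (a 1.7-fold lower number from compound 2 to compound 4 (0.23 log units; within the scatter)) (a 1.3-fold higher number from compound 1 to compound 4 (0.13 log units; within the scatter)). Nothing measured here gives a reason for the shift. Still open, from the compounds shown here alone, is how a ring with a single chlorine would read at this place. Also open, going by these compounds, is what an amine or a carboxylic acid on this ring would do.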